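From compound 2 to compound 3: adding dimethylsulfamoyl

The source may hold more compounds than are shown below. What is called first, only, known or untested is meant among the compounds shown, and "the series" means these compounds.

In a functional assay on PC-6 cells (Homo sapiens) for cytotoxicity, read by MTT assay, with a stated time of 3 days (a lower number here means a stronger inhibitor, a higher number a weaker inhibitor), compound 1 `CC(C)(C)c1cc2c(N/N=C/c3ccc(CO)cc3)ncnc2s1` gives 0.556 ug/mL, while compound 2 `CC(C)(C)c1cc2c(N/N=C/c3ccccc3)ncnc2s1` gives 6.54 ug/mL, the higher of the two numbers. Compound 3 `CN(C)S(=O)(=O)c1ccc(/C=N/Nc2ncnc3sc(C(C)(C)C)cc23)cc1` carries dimethylsulfamoyl in place of hydrogen on an aromatic carbon of compound 2 (dimethylsulfamoyl in place of hydrogen on an aromatic carbon). Among the compounds with values here, only one measured step bears on this change, a 12-fold higher number from compound 1 to compound 2 (1.07 log units; beyond the scatter), which is large and replaces hydroxymethyl with hydrogen. Read in reverse, it links a substituent with a lower number, but dimethylsulfamoyl is a different group. A smaller step in the same direction is therefore expected, an estimated 3.0-fold lower number from compound 2 to compound 3 (0.47 log units; beyond the scatter). Compound 3 is expected at 2.2 ug/mL, with an estimated range of 0.5 ug/mL to 9 ug/mL.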

Compound 3, half-maximal inhibitory concentration: 2.12 ug/mL
The estimate for compound 3 lay 1.0-fold (0.02 log units) above the measured number; the measured number falls inside the stated range.
By their numbers in this assay, from the lowest: compound 1; then compound 3; then compound 2.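

In this assay, a second substituent at this position, para to a large group, also lowers the number, with a 3.1-fold lower number from compound 2 to compound 3 (0.49 log units; beyond the scatter) on going from hydrogen to dimethylsulfamoyl, a group with 0 hydrogen-bond donors. That gain does not reach the level set by hydroxymethyl, as a 3.8-fold higher number from compound 1 to compound 3 (0.58 log units; beyond the scatter) shows when the two groups are compared directly. Nothing measured here explains either step. Where an amine or a carboxylic acid at this position would fall remains open, as does whether a longer chain ending in hydroxyl would match hydroxymethyl.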